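A few compounds are considered here, and "the series" means these few. Any claim that something is new, unique, unknown or untested is made for them only; others in the source may bear on it.

Three compounds were tested in a functional assay on K562 cells (Homo sapiens) for cytotoxicity, read by sulforhodamine B assay, with a stated time of 48 h, tested at 0.01 uM; on this read-out higher numbers stand for a weaker effect at the one concentration tested and lower numbers for a stronger effect. Compound 1 `COc1cc(-c2cc(/C=C/C(=O)c3ccc(N)cc3)[nH]n2)cc(OC)c1OC` gives 100% in this assay. Compound 2 `COc1ccc(-c2cc(/C=C/C(=O)c3ccc(N)cc3)[nH]n2)cc1OC` differs from it in one place (hydrogen in place of methoxy on an aromatic carbon), and in this assay compound 2 gives 99%; the step is a number 1 percentage points lower from compound 1 to compound 2 (within the scatter). Compound 3 `COc1cc(C(=O)/C=C/c2cc(-c3cc(OC)c(OC)c(OC)c3)n[nH]2)cc(OC)c1OC` is built on a different core, and the difference between the two cores is not broken down here; in this assay compound 3 gives 99%. All three numbers sit near the top of the scale, which at this single concentration means hardly any effect on the cells.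

Compound 4 `COc1ccc(-c2cc(/C=C/C(=O)c3cc(OC)c(OC)c(OC)c3)[nH]n2)cc1OC` has not yet been measured. It differs from compound 3 by hydrogen in place of methoxy on an aromatic carbon, which is the same change as that from compound 1 to compound 2, the place being described in the same words. For compound 4 the expected step is no change at the digits printed from compound 3 to compound 4 (within the scatter), because the earlier step of a number 1 percentage points lower from compound 1 to compound 2 (within the scatter) stayed within the scatter and the three measured numbers all lie within the scatter of one another. Compound 4 is therefore estimated at 99%, with a range from 92% to 105%.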

Compound 4, a percentage reported as activity, at one concentration (the size of the read-out at that concentration, not a potency): 100%
Beside the measured number, compound 4's estimate is 1 percentage points below it; the measured number falls inside the stated range.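

In this assay, putting hydrogen in place of methoxy on an aromatic carbon gives a number 1 percentage points higher from compound 3 to compound 4 (within the scatter), and the same change on the other core gives a step that cannot be told apart from it: the same change on two cores in this assay, a number 1 percentage points lower (within the scatter) from compound 1 to compound 2 and a number 1 percentage points higher (within the scatter) from compound 3 to compound 4, 2 percentage points apart, within the scatter of two such steps On these two cores, then, the change leaves the read-out within its usual scatter, so the near-absence of any visible effect carries over from one core to the other. This does not show that the change is unimportant in general, since all four compounds sit near the top of the scale at a single concentration, where hardly any effect on the cells is seen and a real difference between the cores could stay hidden.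

The compounds shown leave open how this change would behave in compounds with a clear effect on the cells. They also leave open whether a different group at this place, such as a carboxylic acid, a chlorine atom or a longer chain like butoxy, would move the number at all.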